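A few compounds are considered here, and "the series" means these few. Any claim that something is new, unique, unknown or untested is made for them only; others in the source may bear on it.

Measured so far in a functional assay on KB cells (Homo sapiens) for cytotoxicity; on this read-out higher numbers stand for weaker inhibition and lower numbers for stronger inhibition:
- compound 1 `CCCCOC1=CC(=O)c2ccccc2C1=O`: 27000 nM
- compound 2 `CS(=O)(=O)Oc1ccc2c(c1)C(=O)C=CC2=O`: 11600 nM

Compound 1 gives the higher of the two numbers in this assay, so it is the weaker inhibitor of the pair. Compound 2 lies lower, beyond the usual scatter. Going by the values given here, the two differ in more than one place, so they give no clean step.

Compound 3 `O=C1C=C(Oc2ccco2)C(=O)c2ccccc21` is not yet measured. It keeps the core of compound 1 and carries furan-2-yl in place of butyl on an oxygen on an unsaturated carbon.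

Among the compounds with values here, no measured step covers this exchange, so the expectation is loose. Compound 1 at 27000 nM sits at the top of the range so far, which leaves a modest move to stronger inhibition as the likelier direction. The expected size is a 2.5-fold lower number from compound 1 to compound 3 (0.39 log units; beyond the scatter), though no change beyond the scatter remains possible. For compound 3 the estimated value is 11000 nM, with an expected range of 3000 nM to 35000 nM.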

Compound 3, half-maximal inhibitory concentration: 53400 nM
For compound 3 the middle estimate is 4.9-fold (0.69 log units) below the measured one; measured number above the stated range.
By their numbers in this assay, from the lowest: compound 2; then compounds 1 and 3 (each within the scatter of the next).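

In this assay, going by these compounds alone, furan-2-yl in place of butyl on an oxygen on an unsaturated carbon gives a 2.0-fold higher number from compound 1 to compound 3 (0.30 log units; within the scatter), the first clean step at this position. The two groups are not separated on this read-out, although they differ in kind: butyl is an open chain with no ring, while furan-2-yl is a five-membered aromatic ring carrying a hydrogen-bond acceptor. No measurement at hand accounts for this outcome.

Still open, going by these compounds, is whether any group at this place can move the number beyond the scatter, for example a longer chain, a chain ending in an amine, or a carboxylic acid. Compound 2, at 11600 nM, differs from both compound 1 and compound 3 in more than one place, so it gives no reading on this position.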